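Amide and urea variants on a thiazole-fused lactam core

This account rests on a few compounds, and the source may have more. Where it says the series, first, only, none or still open, it means among the compounds named here.

Measured so far in an assay on HEK293 cells for positive allosteric modulation of metabotropic glutamate receptor 5 (Homo sapiens), read by FLIPR, with a stated time of 1 h; on this read-out lower numbers stand for an effect already at smaller amounts and higher numbers for an effect only at larger amounts of compound:
- compound 1, `O=C1NCCc2nc(C#Cc3ccccc3)sc21`: compound 1 gives 112 nM
- compound 2, `CN1CCc2nc(C#Cc3cccc(F)c3)sc2C1`: compound 2 gives only a limit, > 10000 nM; the limit of > 10000 nM in this assay, at which 1 of the 3 values shown sits.
- compound 3, `CC1CC1C(=O)N1CCc2nc(C#Cc3ccccc3)sc2C1`: compound 3 gives 9.4 nM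

Compound 3 stands lowest of the two numbers in this assay; its nearest neighbour is compound 1, whose number lies beyond the scatter above it. Compound 2 reports a limit and not a number, so no order with respect to compound 2 can be drawn. Among the compounds with values here, no step between measured compounds differs in a single place, so no measured step size is available for the change now in question.

Compound 4, `O=C(N1CCCC1)N1CCc2nc(C#Cc3ccccc3)sc2C1`, is not yet measured. Compared with compound 3 the change is pyrrolidin-1-yl in place of 2-methylcyclopropyl on a carbonyl carbon. The acyl group of compound 3 is thus replaced by a carbonyl bearing a ring nitrogen, turning the amide into a urea-type link while keeping the shared core and the alkyne arm unchanged.

Compound 4 is expected to remain in the range of compound 3, with a modest drift to a higher number, a step of a 3.2-fold higher number from compound 3 to compound 4 (0.50 log units; beyond the scatter). Compound 4 is therefore estimated at 30 nM in this assay, between 8 nM and 120 nM.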

Compound 4, half-maximal effective concentration: 9.8 nM
Compound 4: the middle estimate sits 3.1-fold (0.49 log units) above what was measured; the measured number falls inside the stated range.
By their numbers in this assay, from the lowest: compounds 3 and 4 (each within the scatter of the next); then compound 1. At a limit, above all of these: compound 2.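

In this assay, the swap of 2-methylcyclopropyl for pyrrolidin-1-yl on the carbonyl carbon gives a step of a 1.0-fold higher number from compound 3 to compound 4 (0.02 log units; within the scatter). Within the data shown here, this is the only measured single-place step, and it shows that this position can carry either the amide link of compound 3 or the urea-type link of compound 4 with no change beyond the scatter. No measured property offered here accounts for this result.

As far as these compounds go, it remains open whether the same holds for other groups on this carbonyl carbon, such as morpholin-4-yl, dimethylamino or a longer alkyl chain. Among these compounds, the role of the carbonyl itself also remains open: compound 1 and compound 2 differ from compound 3 in more than one place, so no steps to them can be read.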